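This account rests on a few compounds, and the source may have more. Where it says the series, first, only, none or still open, it means among the compounds named here.

Three compounds share one core and differ only in the aryl group attached to it. Compound 1 `Cc1nc(N[C@@H]2C[C@H]3CC[C@@H]2C3)c2cc(-c3ccc(C(F)(F)F)cc3)ccc2n1` gives 771 nM in a functional assay for positive allosteric modulation of GABA-B receptor (Homo sapiens), read by GTPgammaS binding; a lower number here means that less compound is needed, a higher number that more compound is needed for the effect. Compound 2 `Cc1nc(N[C@@H]2C[C@H]3CC[C@@H]2C3)c2cc(-c3ccc(Cl)cc3)ccc2n1` gives 444 nM, and compound 3 `Cc1nc(N[C@@H]2C[C@H]3CC[C@@H]2C3)c2cc(-c3ccccc3Cl)ccc2n1` gives 496 nM. Compound 1 has the highest of the three numbers, yet its nearest neighbour, compound 3, and its furthest, compound 2, both lie within the scatter of it, so no order among the three can be drawn. The step of a 1.7-fold lower number from compound 1 to compound 2 (0.24 log units; within the scatter) puts chloro in place of trifluoromethyl on an aromatic carbon; the step of a 1.1-fold higher number from compound 2 to compound 3 (0.05 log units; within the scatter) puts 2-chlorophenyl in place of 4-chlorophenyl on an aromatic carbon. Neither moves the number beyond the scatter.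

Compound 4 `FC(F)(F)c1ccc(-c2ccc3nc(Cl)nc(N[C@@H]4C[C@H]5CC[C@@H]4C5)c3c2)cc1` has not yet been measured. It differs from compound 1 in this way: chloro in place of methyl on an aromatic carbon. Going by the values given here, the exchange sits on the core, on an aromatic carbon between two ring nitrogen atoms, a place that none of the measured steps touches; those steps alter only the aryl group, and both stay within the scatter. Among the compounds with values here, no measured step therefore bears directly on this change, and the expectation is a step of no more than the scatter in this assay, in no fixed direction. Compound 4 is estimated at 800 nM, with a range from 300 nM to 2200 nM, which corresponds to an expected step of a 1.0-fold higher number from compound 1 to compound 4 (0.02 log units; within the scatter).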

Compound 4, half-maximal effective concentration: 637 nM
Compound 4: middle estimate off by 1.3-fold (0.10 log units), on the high side, within the range that was stated.
By their numbers in this assay, from the lowest: compounds 2, 3, 4 and 1 (each within the scatter of the next).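

In this assay, going by these compounds alone, the carbon between two ring nitrogen atoms, which no earlier step had touched, now has a measured exchange of its own: chloro in place of methyl gives a 1.2-fold lower number from compound 1 to compound 4 (0.08 log units; within the scatter). Within the data shown here, the earlier steps showed only that the aryl group could be exchanged without leaving the scatter, whereas this pair shows the same for one exchange on the shared core, with the trifluoromethyl-bearing aryl group of compound 1 held fixed. Nothing in the data shown explains this outcome.

From the compounds shown here alone, this single pair is all that speaks for the position, so it remains open whether the same exchange would also stay within the scatter with the chlorinated aryl groups of compound 2 and compound 3. Going by these compounds, it also remains open whether an amine, a methoxy group or a longer chain such as propyl on this carbon would move the number beyond the scatter, and in which direction.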